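The source may hold more compounds than are shown below. What is called first, only, known or untested is meant among the compounds shown, and "the series" means these compounds.

Values in an assay on the whole organism (stomach) for inhibition of Catechol O-methyltransferase (Mus musculus), with a stated time of 6 h, at a dose of 30 mg/kg by the oral route; on this read-out lower numbers stand for less inhibition and higher numbers for more inhibition at the one dose given (going by the name of the read-out):
compound 1 `O=C(CCN1CCN(c2ccccc2Cl)CC1)c1cc(O)c(O)c([N+](=O)[O-])c1`: 28%
compound 2 `O=C(COc1ccccc1)c1cc(O)c(O)c([N+](=O)[O-])c1`: 50%
compound 3 `CCN(CC)CCC(=O)c1cc(O)c(O)c([N+](=O)[O-])c1`: 43%

Compound 2 gives the highest of the three numbers; the step of a number 7 percentage points lower from compound 2 to compound 3 (within the scatter) stays within the scatter, while compound 1 lies beyond the scatter below compound 2. Compound 4 `COc1ccc(OCC(=O)c2cc(O)c(O)c([N+](=O)[O-])c2)cc1` differs from compound 2 by methoxy in place of hydrogen on an aromatic carbon, para to a large group. For the measured compounds named here, no measured step touches this aromatic carbon. Going by the values given here, the only step that alters the same region, a number 7 percentage points lower from compound 2 to compound 3 (within the scatter), exchanges the whole phenoxy group and still stays within the scatter. A change that keeps the phenoxy group and adds only methoxy is therefore expected to give no step beyond the scatter, a number 2 percentage points lower from compound 2 to compound 4 (within the scatter). Compound 4 is estimated at 48%, between 30% and 65%.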

Compound 4, a percentage reported as inhibition, in the whole organism at one dose (the size of the read-out at that dose, not a potency): 65%
Beside the measured number, compound 4's estimate is 17 percentage points below it; low and high end bracket the measured number.
By their numbers in this assay, from the lowest: compound 1; then compounds 3 and 2 (each within the scatter of the next); then compound 4.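

In this assay, the aromatic carbon para to a large group responds to substitution: a number 15 percentage points higher from compound 2 to compound 4 (beyond the scatter). A small methoxy on the retained phenoxy group thus gives a step beyond the scatter, whereas replacing the whole phenoxy group gave a number 7 percentage points lower from compound 2 to compound 3 (within the scatter), within it. Nothing available bears on the reason for this gain. Still open, going by these compounds, is whether ethoxy, a longer chain, or an amine or carboxylic acid on this carbon would move the number the same way. Also open, on these data alone, is whether the methoxy gain would carry over to the amine-bearing chains of the series.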